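A few compounds are considered here, and "the series" means these few. Any claim that something is new, unique, unknown or untested is made for them only; others in the source may bear on it.

Compound 3 `Cc1cc(C)c(CN2CCc3c(Cl)cc([C@H](C)CO)c(Cl)c3C2=O)c(=O)[nH]1` is the reference point for this step. In an assay for inhibition of histone-lysine N-methyltransferase EZH2 variant Y641N (Homo sapiens), read by scintillation counting, with a stated time of 60 min, in the presence of a further agent that is not named here (a lower number here means a stronger inhibitor, a higher number a weaker inhibitor), compound 3 gives 17 nM, the only number shown for it; two further entries of compound 3 carry no single number. Repeats in this assay can lie far apart: compound 1 `COC(c1cc(Cl)c2c(c1Cl)C(=O)N(Cc1c(C)cc(C)[nH]c1=O)CC2)C1CCOCC1` gives 310 nM; 0.1 nM (2 entries) and compound 2 `COC(c1cc(Cl)c2c(c1Cl)C(=O)N(Cc1c(C)cc(C)[nH]c1=O)CC2)C1CCS(=O)(=O)CC1` gives 93 nM; 0.35 nM (2 entries), and the several entries of compound 1 the several entries of compound 1 in this assay, 310 nM; 0.1 nM (2 entries) and of compound 2 the several entries of compound 2 in this assay, 93 nM; 0.35 nM (2 entries) show how wide the spread between entries can be. Compound 4 `Cc1cc(C)c(CN2CCc3c(Cl)cc([C@@H](CO)[C@H]4CCCO4)c(Cl)c3C2=O)c(=O)[nH]1` carries oxolan-2-yl in place of methyl on a saturated chain carbon bound to an aromatic carbon and a saturated chain carbon. Among the compounds with values here, no measured pair isolates this change. The step in this assay is expected to be a 1.7-fold lower number from compound 3 to compound 4 (0.23 log units; within the scatter), not beyond the usual scatter. Compound 4 is estimated at 10 nM, with a range from 2 nM to 60 nM.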

Compound 4, inhibition constant: 110 nM
For compound 4 the middle estimate is 11-fold (1.04 log units) below the measured one, outside the stated range (above it).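

In this assay, within the data shown here, the first one-place step puts oxolan-2-yl in place of methyl on a saturated chain carbon bound to an aromatic carbon and a saturated chain carbon (a 6.5-fold higher number from compound 3 to compound 4 (0.81 log units; beyond the scatter)). At this position, the larger ring therefore comes with a weaker number, not a stronger one. The size of the step stays uncertain, since entries for a single compound can lie far apart: the several entries of compound 1 in this assay, 310 nM; 0.1 nM (2 entries)

Open, going by these compounds, is how an amine or a longer chain would fare on this carbon. Cyclopentyl there would show whether the ring oxygen matters to the step.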